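The source may hold more compounds than are shown below. What is called first, only, known or untested is meant among the compounds shown, and "the series" means these compounds.

In a functional assay on Caco-2 cells (Homo sapiens) for inhibition, read by MTT assay, with a stated time of 48 h (on this read-out lower numbers stand for stronger inhibition of growth and higher numbers for weaker inhibition of growth), compound 2 `CN1CC[C@H](c2c(O)cc(O)c3c(=O)cc(/C=C/c4cccc(F)c4)oc23)[C@H](O)C1` gives 8000 nM and compound 1 `CN1CC[C@H](c2c(O)cc(O)c3c(=O)cc(/C=C/c4c(F)c(F)c(F)c(F)c4F)oc23)[C@H](O)C1` gives 8000 nM, so the two stand level at the digits available. Compound 3 `CN1CC[C@H](c2c(O)cc(O)c3c(=O)cc(/C=C/c4ccccc4F)oc23)[C@H](O)C1` keeps the shared core and differs from compound 2 only in the group on the chain: 2-fluorophenyl in place of 3-fluorophenyl on a double-bonded chain carbon bound to a double-bonded chain carbon. In words, 2-fluorophenyl takes the place of 3-fluorophenyl on a double-bonded chain carbon bound to a double-bonded chain carbon. Among the compounds with values here, one measured step bears on this, no change at the digits printed from compound 1 to compound 2 (within the scatter), a change at the same place that stayed within the scatter. Within the data shown here, no measured compound carries 2-fluorophenyl, so this single step is thin evidence. Even so, no shift beyond the scatter is expected in this assay, and no direction is favoured. The expected step is no change at the digits printed from compound 2 to compound 3 (within the scatter). For compound 3 the estimated value is 8000 nM, with an expected range of 4000 nM to 16000 nM.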

Compound 3, concentration for 50% growth inhibition: 7000 nM
Beside the measured number, compound 3's estimate is 1.1-fold (0.06 log units) above it; measured number inside the range.
By their numbers in this assay, from the lowest: compounds 3, 1 and 2 (each within the scatter of the next).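

In this assay, 2-fluorophenyl in place of 3-fluorophenyl on a double-bonded chain carbon bound to a double-bonded chain carbon gives a 1.1-fold lower number from compound 2 to compound 3 (0.06 log units; within the scatter) and thus adds a second single-fluorine group to the comparison. The same group in place of 2,3,4,5,6-pentafluorophenyl gives a 1.1-fold lower number from compound 1 to compound 3 (0.06 log units; within the scatter), so all three fluorinated phenyl groups at this place now read alike, and neither where the single fluorine stands nor the change from one fluorine to five separates them in this read-out. Nothing measured here explains this likeness.

From the compounds shown here alone, all three compounds carry fluorine on the phenyl ring, so it remains open whether a plain phenyl, or a phenyl bearing a chlorine, a methoxy group, an amine or a carboxylic acid, would read differently at this place. Going by these compounds, it also remains open whether a change elsewhere on the shared core would move the number more than these changes on the chain.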